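One Group Swap, Measured Once and Expected Again

The source may report more compounds than this note shows. Statements on the series, on what has been measured and on what is new or still open speak of the compounds shown alone.

Four compounds share a common core and differ in two places. Compound 1 `CN1c2ccc(NC(=S)Nc3ccc(C(F)(F)F)cc3)cc2C(C)(C)C(=O)C1(C)C` and compound 2 `CN1c2ccc(NC(=S)Nc3ccc(OC(F)(F)F)cc3)cc2C(C)(C)C(=O)C1(C)C` carry a carbonyl in that core, whereas compound 3 `CN1c2ccc(NC(=S)Nc3ccc(C(F)(F)F)cc3)cc2C(C)(C)C(O)C1(C)C` and compound 4 `CN1c2ccc(NC(=S)Nc3ccc(OC(F)(F)F)cc3)cc2C(C)(C)C(O)C1(C)C` carry a hydroxyl there instead; the difference between the two cores is not broken down here. Within each pair the change is the same: trifluoromethoxy in place of trifluoromethyl on an aromatic carbon for the first pair and trifluoromethoxy in place of trifluoromethyl on an aromatic carbon for the second, and the two place descriptions match word for word, so this is the same change made twice.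

In a functional assay on A2780 cells (Homo sapiens) for inhibition, with a stated time of 72 h (a lower number here means a stronger inhibitor, a higher number a weaker inhibitor), compound 1 gives 3900 nM and compound 2 gives 5400 nM, which makes the step of a 1.4-fold higher number from compound 1 to compound 2 (0.14 log units; within the scatter). Compound 3 gives 7600 nM in this assay, and compound 4 has not yet been measured there.

Among the measured compounds shown here, since the only measured instance of this change, a 1.4-fold higher number from compound 1 to compound 2 (0.14 log units; within the scatter), stayed inside the usual spread of repeat measurements, the expectation for compound 4 is a step of about the same size and direction, namely a 1.4-fold higher number from compound 3 to compound 4 (0.14 log units; within the scatter). On that basis compound 4 is estimated at 10500 nM in this assay, with a plausible range running from 5000 nM to 22000 nM. That expectation rests on a single earlier step, so it is held loosely.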

Compound 4, half-maximal inhibitory concentration: 13100 nM
Estimate against measurement, compound 4: 1.2-fold (0.10 log units) below; the measured number falls inside the stated range.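

In this assay, the swap of trifluoromethyl for trifluoromethoxy on the core that carries a hydroxyl gives a 1.7-fold higher number from compound 3 to compound 4 (0.24 log units; within the scatter), and the comparison with the same swap on the core that carries a carbonyl reads: the same change on two cores in this assay, a 1.4-fold higher number (0.14 log units; within the scatter) from compound 1 to compound 2 and a 1.7-fold higher number (0.24 log units; within the scatter) from compound 3 to compound 4, 1.2-fold (0.10 log units) apart, within the scatter of two such steps

For these two cores, then, the swap behaves alike, and a step read on one core was a fair guide to the step on the other. It does not show that the swap changes the number at all, as each step on its own lies within the spread of repeat measurements, and two cores in one cell assay cannot establish that the swap would behave the same way on any other core in this series.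

The compounds shown carry only trifluoromethyl or trifluoromethoxy on that aromatic carbon, so it stays open whether a nitrile, a methyl group or a chlorine atom in that place would move the number beyond the scatter. They also carry only a carbonyl or a hydroxyl at the other varied place in the core, which leaves open how an amine there would behave and whether the swap would still carry across to such a core.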